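A few compounds are considered here, and "the series" means these few. Any claim that something is new, unique, unknown or untested is made for them only; others in the source may bear on it.

Compound 3 `C=CC(=O)Nc1ccc(-c2nc(Cl)cc(Nc3ccc(C(=O)Nc4ccc(F)cc4)cc3)n2)cc1` is one member of a short series sharing a common core, and in a functional assay on HL-60 cells (Homo sapiens) for antiproliferative activity, read by MTT assay, with a stated time of 48 h (on this read-out lower numbers stand for stronger inhibition and higher numbers for weaker inhibition), its result for compound 3 is given only as "not determined" (no result reported), so it has no number of its own. The two neighbours that were measured give a rough sense of the level: compound 1 `C=CC(=O)Nc1ccc(-c2nc(Cl)cc(Nc3ccc(C(=O)N(CC)CC)cc3)n2)cc1` gives 9340 nM in this assay, and compound 2 `C=CC(=O)Nc1ccc(-c2nc(Cl)cc(Nc3ccc(C(=O)N4CCCC4)cc3)n2)cc1` gives 15800 nM. Among the compounds with values here, the step of a 1.7-fold higher number from compound 1 to compound 2 (0.23 log units; within the scatter) is the only measured step in the set.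

Compound 4 `C=CC(=O)Nc1ccc(-c2nc(Cl)cc(Nc3ccc(C(=O)Nc4cc(C)ccc4C)cc3)n2)cc1` differs from compound 3 by the change (2,5-dimethylphenyl in place of 4-fluorophenyl on an amide-type nitrogen). Within the data shown here, the one measured step concerns a different site, the substituents on the carbonyl carbon rather than on the amide-type nitrogen, and it stayed within the scatter, so it bears on this change only in showing that variation of the amide portion left this assay largely unmoved for compound 1 and compound 2. For the step from compound 3 to compound 4 no direction can be read from the data beyond that, and no change beyond the scatter is expected.

On that basis compound 4 is estimated at 11000 nM in this assay, with a wide range from 2500 nM to 50000 nM reflecting the missing anchor of compound 3.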

Compound 4, half-maximal inhibitory concentration: 14900 nM
Estimate against measurement, compound 4: 1.4-fold (0.13 log units) below; low and high end bracket the measured number.
By their numbers in this assay, from the lowest: compounds 1, 4 and 2 (each within the scatter of the next).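

In this assay, compound 4 brings the first measured aryl-bearing amide nitrogen into the set, with (2,5-dimethylphenyl)amino on the carbonyl carbon where the earlier measured compounds carry pyrrolidin-1-yl or diethylamino. That exchange gives a 1.1-fold lower number from compound 2 to compound 4 (0.03 log units; within the scatter) and a 1.6-fold higher number from compound 1 to compound 4 (0.20 log units; within the scatter), so even a group with an aromatic ring at this place leaves the result within the scatter of both earlier values, and the three measured compounds form one flat group with no order among them. The step from 4-fluorophenyl to 2,5-dimethylphenyl on the amide-type nitrogen cannot be read, as compound 3 has no number, and no measurement here offers any explanation for the flatness of the series.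

The compounds shown leave open whether any group on the carbonyl carbon can move this number beyond the scatter, for example a morpholin-4-yl group, or a phenylamino group carrying a carboxylic acid or an amine. They also leave open where the 4-fluorophenyl of compound 3 would fall relative to the other three compounds.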